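The compounds below may be only part of what the source reports. "The series", "measured", "known", "first", "only" and "open" are said of these compounds alone.

In an ADME assay on microsomes from liver (Homo sapiens) for metabolic stability, read by LC-MS, using NADPH, with stated times of 5 min and 30 min, tested at 1 uM (a lower number here means slower removal, a higher number faster removal of the compound), compound 1 `CN(c1ncco1)c1cnc(NCc2c(F)ccc3c2CCO3)n2cnnc12` gives 11 mL.min-1.g-1. Compound 2 `COCCC(=O)Nc1cnc(NCc2c(F)ccc3c2CCO3)n2cnnc12` gives < 3 mL.min-1.g-1, which is a limit of the assay and not a number. Compound 3 `O=C(Nc1cnc(NCc2c(F)ccc3c2CCO3)n2cnnc12)c1cccnc1` gives < 3 mL.min-1.g-1, which is also a limit. Compound 3 therefore stands at the limit of < 3 mL.min-1.g-1 in this assay, at which 2 of the 3 values shown sit, and compound 2 shares that position.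

Compound 4 `C[C@H]1CC(=O)N(c2cnc(NCc3c(F)ccc4c3CCO4)n3cnnc23)C1` carries 4-methyl-2-oxopyrrolidin-1-yl in place of ((pyridin-3-yl)carbonyl)amino on an aromatic carbon.

Going by the values given here, two measured steps bear on this change. One is an at least 3.6-fold lower number from compound 1 to compound 2 (0.56 log units; beyond the scatter), and the other is an at least 3.6-fold lower number from compound 1 to compound 3 (0.56 log units; beyond the scatter). Both lie beyond the scatter, and both begin from the methyl(1,3-oxazol-2-yl)amino group. The remaining step, a step that the two limits leave unreadable from compound 2 to compound 3, gives no size to carry forward.

The entering group matches neither measured type exactly. It keeps a carbonyl, as in compound 2 and compound 3, but has no hydrogen-bond donor, as in compound 1. Compound 4 is thus expected to lie near the amides, perhaps somewhat towards compound 1 at 11 mL.min-1.g-1. The expected change is an at least 1.3-fold higher number from compound 3 to compound 4 (0.12 log units; that floor lies within the scatter), a modest rise that may not be readable if compound 4 also reaches the limit. Compound 4 is estimated at 4 mL.min-1.g-1, with an expected range of 2 mL.min-1.g-1 to 11 mL.min-1.g-1.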

Compound 4, intrinsic clearance in microsomes: < 3 mL.min-1.g-1
Compound 4: no number, only a limit; the forecaster's own chance of this, stated with the estimate: 40%; middle value at least 1.3-fold (0.12 log units) from the limit.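

In this assay compound 4 gives < 3 mL.min-1.g-1, which is a limit of the assay and not a number. The 4-methyl-2-oxopyrrolidin-1-yl group has no hydrogen-bond donor, yet in place of methyl(1,3-oxazol-2-yl)amino at this position it gives an at least 3.6-fold lower number from compound 1 to compound 4 (0.56 log units; beyond the scatter), so among the compounds shown the amide hydrogen of compound 2 and compound 3 is not needed to reach this limit. The steps from compound 2 and from compound 3 to compound 4 cannot be read, and the three carbonyl-bearing groups cannot be ordered, as all of them stand at one place: the limit of < 3 mL.min-1.g-1 in this assay, at which 3 of the 4 values shown sit.

The compounds shown leave open how far below the limit these three lie, and whether the carbonyl itself goes with the lower reading, which a morpholin-4-yl group at this position, a ring amine without a carbonyl, would help to test. They also leave open whether the methyl group and its defined stereocentre matter, which the plain 2-oxopyrrolidin-1-yl group or the opposite stereoisomer of compound 4 could address only in an assay reading above the limit.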